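The compounds below may be only part of what the source reports. "The series", "measured", "known", "first", "only" and "open" are said of these compounds alone.

Working notes. In a functional assay on C6 cells (Rattus norvegicus), read by thymidine incorporation (on this read-out higher numbers stand for weaker inhibition and lower numbers for stronger inhibition), compound 1 `CCCCCCCCCCCCCCCCO[C@H]1O[C@H](CO)[C@@H](O)[C@H](O)[C@H]1NC(C)=O` gives 13 uM. Compound 2 `C=CCCC(=O)N[C@H]1[C@@H](OCCCCCCCCCCCCCCCC)O[C@H](CO)[C@@H](O)[C@@H]1O` reaches only the limit of > 50 uM in this assay. The step of an at least 3.8-fold higher number from compound 1 to compound 2 (0.58 log units; beyond the scatter) therefore rests on a limit, as shown by the limit of > 50 uM in this assay, at which 1 of the 2 values shown sits. Compound 3 `C=CCCC(=O)N[C@H]1[C@@H](OCCCCCCCCCCCCCCCC)O[C@H](CO)[C@@H](O)[C@@H]1OS(=O)(=O)O` differs from compound 2 by sulfo in place of hydrogen on an oxygen on a saturated carbon. None of the measured steps concerns this change; the only step shown touches a different group, so no direction beyond the scatter can be drawn from it. Compound 3 is expected to stay near the limit region, with an estimated step that the limit leaves unreadable from compound 2 to compound 3. Compound 3 is estimated at 60 uM, within 15 uM to 200 uM.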

Compound 3, concentration for 50% inhibition: 22.6 uM
Beside the measured number, compound 3's estimate is 2.7-fold (0.42 log units) above it, and the stated range covers the measured number.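

In this assay, among the compounds shown here, the hydroxy to sulfooxy change gives an at least 2.2-fold lower number from compound 2 to compound 3 (0.34 log units; beyond the scatter), so this oxygen is the first place where a change moves the read-out towards stronger inhibition. The earlier step, at the carbonyl side chain, ran the other way. For compound 2 the value is only a limit, so the size of this step stays a lower bound: the limit of > 50 uM in this assay, at which 1 of the 3 values shown sits.

From the compounds shown here alone, whether a smaller group on the same oxygen, such as methyl, or a carboxylic acid there would give a similar step stays open. So does the effect of sulfooxy with the acetyl amide of compound 1.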